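The source may hold more compounds than are shown below. What is called first, only, known or untested is meant among the compounds shown, and "the series" means these compounds.

Compounds measured so far in a functional assay on MCF7 cells (Homo sapiens) for antiproliferative activity, read by sulforhodamine B assay, with a stated time of 72 h; a higher number here means a weaker inhibitor, a lower number a stronger inhibitor
compound 1 `COc1cccc(/C=C2\CCC=CC2=O)c1` gives 2030 nM
compound 2 `O=C1C=CCC/C1=C\c1ccc(OC(F)(F)F)cc1` gives 1040 nM
compound 3 `COc1ccc(/C=C2\CCC=CC2=O)cc1OC` gives 5230 nM

The values of compound 1 and compound 2 lie within the usual scatter of each other, so the two cannot be told apart. Within the data shown here, the only measured step from compound 1 is a 2.6-fold higher number from compound 1 to compound 3 (0.41 log units; beyond the scatter), a modest change that places methoxy in place of hydrogen on an aromatic carbon.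

The next compound to be read is compound 4 `COc1cccc(/C=C2\CCC=CC2=O)c1OC`. Its change from compound 1 is methoxy in place of hydrogen on an aromatic carbon. In words, this is methoxy in place of hydrogen on an aromatic carbon, ortho to a methoxy group.

The step to compound 3 is the same kind of change, although the new methoxy stands on a different carbon there, so it is a guide and not a direct transfer. It is also a single example. Among the measured compounds shown here, compound 2 offers no comparable step. A modest move to a higher number is therefore expected in this assay, in the same direction and of about the same size. The expected step is a 2.2-fold higher number from compound 1 to compound 4 (0.35 log units; beyond the scatter). For the half-maximal inhibitory concentration of compound 4 the estimate is 4500 nM, with an expected range of 2000 nM to 10000 nM.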

Compound 4, half-maximal inhibitory concentration: 4710 nM
For compound 4 the middle estimate is 1.0-fold (0.02 log units) below the measured one; the measured number falls inside the stated range.
By their numbers in this assay, from the lowest: compounds 2 and 1 (each within the scatter of the next); then compounds 4 and 3 (each within the scatter of the next).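

In this assay, methoxy in place of hydrogen on an aromatic carbon, ortho to a methoxy group, gives a 2.3-fold higher number from compound 1 to compound 4 (0.37 log units; beyond the scatter), so this position also responds to the change with a step beyond the scatter. The earlier example, a 2.6-fold higher number from compound 1 to compound 3 (0.41 log units; beyond the scatter), put the new methoxy on a different carbon; with two steps now running in the same direction, a second methoxy goes with a higher number at both carbons tested, and no compound shown goes against this. Nothing measured here speaks to what lies behind the step.

The compounds shown leave open whether the higher number goes with methoxy in particular or with any group on this carbon, and a hydroxyl group, a fluorine atom or an amine there would bear on that question. Among these compounds, also open is whether the same step would appear on compound 2, which gives 1040 nM and carries trifluoromethoxy rather than methoxy, so the change has so far been read only against the single methoxy of compound 1.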